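A few compounds are considered here, and "the series" means these few. Any claim that something is new, unique, unknown or untested is made for them only; others in the source may bear on it.

In a functional assay on A549 cells (Homo sapiens) for antiproliferative activity, read by MTT assay, with a stated time of 72 h (on this read-out higher numbers stand for weaker inhibition and lower numbers for stronger inhibition), compound 1 `O=C(N/N=C/c1ccccc1)Nc1ccc(Oc2ccnc3[nH]ccc23)c(F)c1` gives 2500 nM and compound 2 `O=C(N/N=C/c1ccc(F)cc1)Nc1ccc(Oc2ccnc3[nH]ccc23)c(F)c1` gives 680 nM while compound 3 `O=C(N/N=C/c1ccccc1)Nc1ccc(Oc2ccnc3[nH]ccc23)cc1` gives 17200 nM as the highest of the three numbers. Compound 3 is thus the weakest of the set so far, and the question is whether a small change can improve it. Compound 4 `O=C(N/N=C/c1ccc(F)cc1)Nc1ccc(Oc2ccnc3[nH]ccc23)cc1` has not been measured yet. Its difference from compound 3 is fluoro in place of hydrogen on an aromatic carbon and in words this is fluoro in place of hydrogen on an aromatic carbon, which turns phenyl to 4-fluorophenyl.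

For the measured compounds named here, the closest precedent is a 3.7-fold lower number from compound 1 to compound 2 (0.57 log units; beyond the scatter). That step is the same phenyl to 4-fluorophenyl change, made on a compound that keeps a fluoro on the shared core. The other measured step is a 6.9-fold higher number from compound 1 to compound 3 (0.84 log units; beyond the scatter) and it shows what losing that core fluoro did, but it is a different change. Whether the gain carries over to a compound without the core fluoro is not known. A lower number of similar size is therefore expected, and the estimated step is a 3.7-fold lower number from compound 3 to compound 4 (0.57 log units; beyond the scatter) in this comparison. Compound 4 is estimated at 4600 nM with an expected range from 1800 nM to 11000 nM in repeat measurements.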

Compound 4, half-maximal inhibitory concentration: 1430 nM
For compound 4 the middle estimate is 3.2-fold (0.51 log units) above the measured one; measured number below the stated range.
By their numbers in this assay, from the lowest: compound 2; then compounds 4 and 1 (each within the scatter of the next); then compound 3.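

In this assay, the change from phenyl to 4-fluorophenyl, with the fluoro para to a large group, gives a 12-fold lower number from compound 3 to compound 4 (1.08 log units; beyond the scatter), so the gain seen earlier also appears on the core without the core fluoro, and its size depends on the core that carries it: the same change on two cores in this assay, a 3.7-fold lower number (0.57 log units; beyond the scatter) from compound 1 to compound 2 and a 12-fold lower number (1.08 log units; beyond the scatter) from compound 3 to compound 4, 3.3-fold (0.51 log units) apart, beyond the scatter of two such steps

The core fluoro also counts for less once the 4-fluorophenyl group is present, as its loss there gives a 2.1-fold higher number from compound 2 to compound 4 (0.32 log units; beyond the scatter), a smaller step than on the compounds with a plain phenyl: the same change on two cores in this assay, a 6.9-fold higher number (0.84 log units; beyond the scatter) from compound 1 to compound 3 and a 2.1-fold higher number (0.32 log units; beyond the scatter) from compound 2 to compound 4, 3.3-fold (0.51 log units) apart, beyond the scatter of two such steps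

The effects of the two fluoro groups therefore do not simply add up, since each step is smaller when the other fluoro is already present, although compound 2, which carries both, still gives the lowest number of the set.

From the compounds shown here alone, whether a chlorine atom, a methoxy group or an amine in the same place on the phenyl ring would give a similar step remains open. Also open is why the step changes with the core fluoro, as numbers from a cell growth read-out alone cannot tell.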